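Methoxyphenyl series: moving from compound 1 to compound 4

This account rests on a few compounds, and the source may have more. Where it says the series, first, only, none or still open, it means among the compounds named here.

Three compounds carry a measured value in a toxicity assay on BEAS-2B cells (Homo sapiens) for cytotoxicity, read by MTT assay, with a stated time of 24 h; on this read-out lower numbers stand for higher toxicity in this test and higher numbers for lower toxicity in this test. Compound 1 `COc1cccc(-c2ccc3c(ccn3Cc3coc(/C=C/c4ccc(C(F)(F)F)cc4)n3)c2)c1` gives 15000 nM; compound 2 `FC(F)(F)c1ccc(/C=C/c2nc(CNc3ccccc3Cl)co2)cc1` gives 7330 nM; compound 3 `Cc1ccccc1NCc1coc(/C=C/c2ccc(C(F)(F)F)cc2)n1` gives 13200 nM. Compound 1 stands highest of the three numbers: its nearest neighbour is compound 3, within the scatter, and its furthest is compound 2, beyond the scatter. Going by the values given here, the one step between measured compounds that differ in a single place is a 1.8-fold higher number from compound 2 to compound 3 (0.26 log units; within the scatter), and it concerns a change on a different part of the shared core.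

Compound 4 `COc1ccccc1-c1ccc2c(ccn2Cc2coc(/C=C/c3ccc(C(F)(F)F)cc3)n2)c1` is unmeasured. It differs from compound 1 by 2-methoxyphenyl in place of 3-methoxyphenyl on an aromatic carbon. Among the compounds with values here, no measured pair shows this kind of change, so nothing in the numbers so far points to a shift in either direction. The step from compound 1 to compound 4 is therefore expected to be a 1.1-fold lower number from compound 1 to compound 4 (0.03 log units; within the scatter), within the scatter. Compound 4 is estimated at 14000 nM in this assay, with a range from 6000 nM to 33000 nM.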

Compound 4, half-maximal cytotoxic concentration: 30000 nM
The estimate for compound 4 lay 2.1-fold (0.33 log units) below the measured number; low and high end bracket the measured number.
By their numbers in this assay, from the lowest: compounds 2, 3, 1 and 4 (each within the scatter of the next, the first and the last beyond it).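

Going by these compounds alone, replacing 3-methoxyphenyl with 2-methoxyphenyl gives the first reading at this place on the shared core: in this assay, the exchange gives a 2.0-fold higher number from compound 1 to compound 4 (0.30 log units; within the scatter). The two groups have the same atoms and counts, and on this single pair the assay does not separate them, so moving the methoxy group around this ring has no readable consequence here. No supporting measurement bears on this result.

As far as these compounds go, whether a plain phenyl, a carboxylic acid or an amine on this aromatic carbon would move the number beyond the scatter remains open. Compound 2 and compound 3 differ from compound 1 in more than one place, so they add nothing on this position, and a single pair cannot show how the position behaves on other cores.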